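The source may report more compounds than this note shows. Statements on the series, on what has been measured and on what is new or still open speak of the compounds shown alone.

Working notes on the series of alkyl-substituted pyrogallol ketones.

Compound 1 `CCCCCCCCC(=O)c1cc(O)c(O)c(O)c1` is taken as the reference point. In a functional assay on L1210 cells (Mus musculus) for cytotoxicity, read by MTT assay, with a stated time of 72 h (on this read-out lower numbers stand for stronger inhibition and higher numbers for weaker inhibition), compound 1 gives 22000 nM. Compound 2 `CCCCCCCCCCC(=O)c1cc(O)c(O)c(O)c1` gives 15500 nM in this assay, and compound 3 `CCCCCCCCCCCCC(=O)c1cc(O)c(O)c(O)c1` gives 21000 nM. Compound 1 stands at one end of the three numbers shown, but its separation from the others is slight: a 1.0-fold lower number from compound 1 to compound 3 (0.02 log units; within the scatter), and a 1.4-fold lower number from compound 1 to compound 2 (0.15 log units; within the scatter). The remaining pair also sits together, a 1.4-fold higher number from compound 2 to compound 3 (0.13 log units; within the scatter), so nothing across these three compounds is resolved beyond the scatter.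

Compound 4 `CCCCCCCCCCCCCCC(=O)c1cc(O)c(O)c(O)c1` is not yet measured in this assay. It differs from compound 1 by hexyl in place of hydrogen on a saturated chain carbon, eight bonds along the chain from a carbonyl carbon. For the measured compounds named here, the steps that bear on this are the two chain extensions already made from compound 1, each at the same place on the chain: the ethyl extension and the butyl extension, both of which left the number where it was within the scatter. Extending the same chain further by hexyl is therefore expected to move the number in this assay little, with no direction beyond the scatter indicated.

The estimate for compound 4 in this assay is 20000 nM, with a range from 9000 nM to 45000 nM, which corresponds to an expected step of a 1.1-fold lower number from compound 1 to compound 4 (0.04 log units; within the scatter).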

Compound 4, half-maximal inhibitory concentration: 12500 nM
The estimate for compound 4 lay 1.6-fold (0.20 log units) above the measured number; low and high end bracket the measured number.
By their numbers in this assay, from the lowest: compounds 4, 2, 3 and 1 (each within the scatter of the next).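

In this assay the largest change so far, hexyl in place of hydrogen on a saturated chain carbon, eight bonds along the chain from a carbonyl carbon, still stays within the scatter (a 1.8-fold lower number from compound 1 to compound 4 (0.25 log units; within the scatter)), so the flat picture given by the ethyl and butyl extensions now reaches hexyl. Ethyl placed on a longer chain also stays within the scatter (a 1.7-fold lower number from compound 3 to compound 4 (0.23 log units; within the scatter)), and it reads the same as the earlier ethyl step on a shorter chain: the same change on two cores in this assay, a 1.4-fold lower number (0.15 log units; within the scatter) from compound 1 to compound 2 and a 1.7-fold lower number (0.23 log units; within the scatter) from compound 3 to compound 4, 1.2-fold (0.07 log units) apart, within the scatter of two such steps. Butyl on a longer chain does the same (a 1.2-fold lower number from compound 2 to compound 4 (0.09 log units; within the scatter)), again in agreement with the earlier butyl step: the same change on two cores in this assay, a 1.0-fold lower number (0.02 log units; within the scatter) from compound 1 to compound 3 and a 1.2-fold lower number (0.09 log units; within the scatter) from compound 2 to compound 4, 1.2-fold (0.07 log units) apart, within the scatter of two such steps.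

Going by these compounds, whether a shorter chain, a longer chain or a chain carrying an amine or a carboxylic acid would move the number beyond the scatter remains open. With all four compounds sitting within the scatter of one another, no best chain length can be named, and whether cytotoxicity in this assay depends on this chain at all is unresolved.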